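The compounds below may be only part of what the source reports. "The series", "measured", "known", "first", "only" and "open" are said of these compounds alone.

In an assay on Sf9 cells for inhibition of mitogen-activated protein kinase kinase kinase 20 (Homo sapiens), read by ADP-Glo, with a stated time of 30 min (a higher number here means a weaker inhibitor, a lower number a stronger inhibitor), compound 1 `Nc1ccc(-c2cn(-c3c(F)ccc(NS(=O)(=O)c4cccc(Cl)c4)c3F)nn2)cn1` gives 46.2 nM, while compound 2 `COc1n[nH]c2ncc(-c3cn(-c4c(F)ccc(NS(=O)(=O)c5ccccc5)c4F)nn3)cc12` gives 3.8 nM, the lowest of the two numbers and a gap beyond the scatter. Compound 3 `COc1n[nH]c2ncc(-c3cn(-c4c(F)ccc(NS(=O)(=O)c5ccc6ccccc6c5)c4F)nn3)cc12` is not yet measured; it differs from compound 2 by naphthalen-2-yl in place of phenyl on a sulfonyl sulfur. Within the data shown here, no measured pair shows this change, so the size of the step cannot be read from the data. A step no larger than the scatter, in either direction, is expected, so that the estimated change from compound 2 to compound 3 is a 1.2-fold higher number from compound 2 to compound 3 (0.07 log units; within the scatter). Compound 3 is thus expected to give 4.5 nM in this assay, within a range from 1.5 nM to 14 nM.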

Compound 3, half-maximal inhibitory concentration: 4.5 nM
Compound 3: middle estimate and measured number agree at the digits printed; the measured number falls inside the stated range.
By their numbers in this assay, from the lowest: compounds 2 and 3 (each within the scatter of the next); then compound 1.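

In this assay, naphthalen-2-yl in place of phenyl on a sulfonyl sulfur gives a 1.2-fold higher number from compound 2 to compound 3 (0.07 log units; within the scatter). This position therefore accepts a second six-membered aromatic ring of carbon only without a step beyond the scatter, which compounds 1 and 2, differing in more than one place, could not show. Nothing shown gives a reason for this result. From the compounds shown here alone, it remains open whether cyclohexyl or a short alkyl chain on the sulfonyl sulfur, or a phenyl carrying an amine or a carboxylic acid, would give a similarly low number.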